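The source may report more compounds than this note shows. Statements on the series, on what has been measured and on what is new or still open speak of the compounds shown alone.

In an ADME assay on HEL cells (Homo sapiens) for cytotoxicity, with a stated time of 3 days (on this read-out lower numbers stand for higher toxicity in this test and higher numbers for lower toxicity in this test), compound 1 `Cc1cc(-c2ccc(O)cc2)cn2c(CSCCc3ccccc3)cnc12` gives only a limit of the test rather than a number, >= 100 ug/mL; this is the limit of >= 100 ug/mL in this assay, at which 1 of the 3 values shown sits. Compound 2 `COc1cccc(-c2cc(C)cn3c(CSCCc4ccccc4)cnc23)c1` gives 100 ug/mL and compound 3 `Cc1cc(-c2cccs2)c2ncc(CSCCc3ccccc3)n2c1` gives 100 ug/mL. For the measured compounds named here, the one step measured on this shared core, no change at the digits printed from compound 2 to compound 3 (within the scatter), left the read-out unchanged when one aromatic group replaced another. Compound 4 `Cc1cc(-c2cccs2)cn2c(CSCCc3ccccc3)cnc12` differs from compound 1 by thiophen-2-yl in place of 4-hydroxyphenyl on an aromatic carbon. Compound 3 already carries the entering group and gives 100 ug/mL, so no step beyond the scatter is expected here either. Compound 4 is therefore expected to give 100 ug/mL, within a range from 50 ug/mL to 200 ug/mL, an expected step of a number no higher from compound 1 to compound 4 (the limit leaves the size open).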

Compound 4, minimum cytotoxic concentration: 20 ug/mL
Compound 4: middle estimate off by 5.0-fold (0.70 log units), on the high side; measured number below the stated range.
By their numbers in this assay, from the lowest: compound 4; then compounds 2 and 3 (each within the scatter of the next).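

Replacing 4-hydroxyphenyl with thiophen-2-yl at this position gives an at least 5.0-fold lower number from compound 1 to compound 4 (0.69 log units; beyond the scatter) in this assay, so the aromatic group here can matter for toxicity in this test. The earlier exchange of aromatic groups, at another place on the core, gave no change at the digits printed from compound 2 to compound 3 (within the scatter) and showed no such shift. On these data alone, for compound 1, >= 100 ug/mL is a limit, so the full size of the new step stays unknown: the limit of >= 100 ug/mL in this assay, at which 1 of the 4 values shown sits.

The compounds shown cannot separate losing the hydroxyl from gaining the thiophene ring. As far as these compounds go, how a plain phenyl or a 4-aminophenyl group would read at this position remains open.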